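Swapping the methoxypyridine for a hydroxyphenyl

The source may report more compounds than this note shows. Statements on the series, on what has been measured and on what is new or still open speak of the compounds shown alone.

compound 1 `CC1=C(c2nc(-c3ccc(C#N)cc3)cs2)C(c2ccc(F)nc2)NC(=O)N1` gives 49.4% in an ADME assay on microsomes from liver (Rattus norvegicus) for metabolic stability, read by LC-MS, using NADPH, with stated times of 5 min and 60 min, tested at 4 uM; on this read-out higher numbers stand for a more stable compound and lower numbers for a less stable compound
compound 2 `CC1=C(c2nc(-c3ccc(C#N)cc3)cs2)C(c2ccc(Br)nc2)NC(=O)N1` gives 67.6% in this assay
compound 3 `COc1ccc(C2NC(=O)NC(C)=C2c2nc(-c3ccc(C#N)cc3)cs2)cn1` gives 69.4% in this assay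

Compound 3 sits level with compound 2: the data show a number 1.8 percentage points higher from compound 2 to compound 3 (within the scatter), against a number 20 percentage points higher from compound 1 to compound 3 (beyond the scatter) on the other side. Compound 4 `CC1=C(c2nc(-c3ccc(C#N)cc3)cs2)C(c2cccc(O)c2)NC(=O)N1` brings (3-hydroxyphenyl in place of 6-methoxypyridin-3-yl on a saturated ring carbon), that is, 3-hydroxyphenyl in place of 6-methoxypyridin-3-yl on a saturated ring carbon. Among the compounds with values here, no measured step exchanges this whole group. The nearest guides are swaps on an aromatic carbon, a number 18.2 percentage points higher from compound 1 to compound 2 (beyond the scatter) and a number 20 percentage points higher from compound 1 to compound 3 (beyond the scatter), both modest. A modest step is therefore expected, tentatively downward, since compound 3 with 69.4% shares the top of this small set. The expected change is a number 13.4 percentage points lower from compound 3 to compound 4 (beyond the scatter) in this assay. For compound 4 the estimate is 56%, with an expected range from 36% to 76%.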

Compound 4, percent of the compound remaining: 52.4%
The estimate for compound 4 lay 3.6 percentage points above the measured number; the measured number falls inside the stated range.
By their numbers in this assay, from the lowest: compounds 1 and 4 (each within the scatter of the next); then compounds 2 and 3 (each within the scatter of the next).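

Exchanging the whole group on the saturated ring carbon registers in this assay: 3-hydroxyphenyl gives a number 17 percentage points lower from compound 3 to compound 4 (beyond the scatter) and a number 15.2 percentage points lower from compound 2 to compound 4 (beyond the scatter), yet a number 3 percentage points higher from compound 1 to compound 4 (within the scatter). The new group therefore stands level with 6-fluoropyridin-3-yl, not with the methoxy or bromo groups. Nothing available bears on the reason for this.

The aromatic hetero atom and the substituent change together here, so neither can be credited with the drop. 3-Methoxyphenyl would separate them, and 3-aminophenyl would test another replacement for the hydroxy group.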